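Swapping Sulfamoyl for Nitro on a Shared Core

A few compounds are considered here, and "the series" means these few. Any claim that something is new, unique, unknown or untested is made for them only; others in the source may bear on it.

Of the compounds shown here, two of a shared core have been measured in a functional assay on MCF7 cells (Homo sapiens) for antiproliferative activity, read by MTT assay, with a stated time of 72 h; a lower number here means a stronger inhibitor of growth, a higher number a weaker inhibitor of growth. Compound 1, `Cn1nc(-c2ccnc(Nc3ccc([N+](=O)[O-])cc3)n2)c2ccccc21`, carries a nitro group and gives 11800 nM. Compound 2, `CCn1nc(-c2ccnc(Nc3ccc(S(N)(=O)=O)cc3)n2)c2ccccc21`, carries a sulfamoyl group and gives 2280 nM, the lowest of the two numbers; the gap from compound 2 up to compound 1 lies beyond the scatter. Compound 3, `CCn1nc(-c2ccnc(Nc3ccc([N+](=O)[O-])cc3)n2)c2ccccc21`, has not yet been measured. Going from compound 2 to compound 3 the structure changes in one place: nitro in place of sulfamoyl on an aromatic carbon. Among the compounds with values here, no single-change step of this kind has been measured within this set, so its size cannot be read off directly. The pair of compound 1 and compound 2 shows that the nitro-bearing compound has the higher number, although the two also differ elsewhere. On that basis the step from compound 2 to compound 3 is expected to raise the number beyond the scatter, as a 3.9-fold higher number from compound 2 to compound 3 (0.60 log units; beyond the scatter). Compound 3 is therefore estimated at 9000 nM in this assay, with a range from 3000 nM to 27000 nM.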

Compound 3, concentration for 50% growth inhibition: 24000 nM
Beside the measured number, compound 3's estimate is 2.7-fold (0.43 log units) below it; the range from low to high includes it.
By their numbers in this assay, from the lowest: compound 2; then compound 1; then compound 3.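

In this assay, nitro in place of sulfamoyl on an aromatic carbon, para to a large group, can now be read as a single change: it gives an 11-fold higher number from compound 2 to compound 3 (1.02 log units; beyond the scatter), a large step with the rest of the structure held the same, whereas compound 1 and compound 2 also differed elsewhere. The chain on the aromatic nitrogen can also be read on its own for the first time: with nitro in place, methyl in place of hydrogen on a saturated chain carbon bound to an aromatic nitrogen gives a 2.0-fold higher number from compound 1 to compound 3 (0.31 log units; beyond the scatter), a modest step that is still beyond the scatter, so among these compounds the exchange of sulfamoyl for nitro is the larger of the two changes. Nothing shown here gives a reason for either step.

Going by these compounds, it remains open whether an amine, a carboxylic acid or a methylsulfonyl group on this aromatic carbon would give a number nearer that of compound 2 or that of compound 3. On these data alone, it is equally open whether the chain step seen with nitro would carry over to the sulfamoyl series, and whether a longer chain such as propyl would continue the same direction.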